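The source may report more compounds than this note shows. Statements on the series, on what has been measured and on what is new or still open speak of the compounds shown alone.

Measured compounds:
- compound 1 `C/C(=C\COC(=O)NC(C)(C)C)C1=CC(=O)C(C)(C)O1` gives 7.1 ug/mL in a functional assay on FM3A cells (Mus musculus) for inhibition; a higher number here means a weaker inhibitor, a lower number a stronger inhibitor
- compound 2 `C=CCNC(=O)OC/C=C(\C)C1=CC(=O)C(C)(C)O1` gives 7.6 ug/mL in this assay
- compound 3 `C/C(=C\COC(=O)NC1CCCCC1)C1=CC(=O)C(C)(C)O1` gives 13 ug/mL in this assay

All three share one core and differ only in the group attached to an amide-type nitrogen. Compound 3 sits at one end of the three numbers, but its gaps to the others, a 1.8-fold higher number from compound 1 to compound 3 (0.26 log units; within the scatter) and a 1.7-fold higher number from compound 2 to compound 3 (0.23 log units; within the scatter), are both within the scatter, so the three compounds cannot be told apart on these data.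

Compound 4 `C/C(=C\COC(=O)NCc1ccccc1)C1=CC(=O)C(C)(C)O1` is the next variation at the same nitrogen: benzyl in place of cyclohexyl on an amide-type nitrogen. The steps that speak to this change are the three already made at that nitrogen, a 1.1-fold higher number from compound 1 to compound 2 (0.03 log units; within the scatter), a 1.8-fold higher number from compound 1 to compound 3 (0.26 log units; within the scatter) and a 1.7-fold higher number from compound 2 to compound 3 (0.23 log units; within the scatter), none of which moved beyond the scatter. Swapping a saturated ring for an aromatic one joined through one carbon is therefore expected to give no step beyond the scatter: a 1.1-fold lower number from compound 3 to compound 4 (0.03 log units; within the scatter). For compound 4 the estimate in this assay is 12 ug/mL, with a range from 5 ug/mL to 30 ug/mL.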

Compound 4, half-maximal inhibitory concentration: 8.1 ug/mL
For compound 4 the middle estimate is 1.5-fold (0.17 log units) above the measured one; the measured number falls inside the stated range.
By their numbers in this assay, from the lowest: compounds 1, 2, 4 and 3 (each within the scatter of the next).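

Benzyl brings an aromatic ring to this amide-type nitrogen, and in this assay it still gives no step beyond the scatter against cyclohexyl (a 1.6-fold lower number from compound 3 to compound 4 (0.21 log units; within the scatter)), against allyl (a 1.1-fold higher number from compound 2 to compound 4 (0.03 log units; within the scatter)) or against tert-butyl (a 1.1-fold higher number from compound 1 to compound 4 (0.06 log units; within the scatter)). The position has therefore now held tert-butyl, allyl, a six-membered non-aromatic ring and a six-membered aromatic ring, and all four compounds remain indistinguishable on these data. No measurement here offers an explanation for this flat picture.

On these data alone, all four groups contain only carbon, so it remains open whether an amine, a carboxylic acid or a longer chain at this nitrogen would produce a step beyond the scatter. As far as these compounds go, the effect of changing any other part of the shared core also remains unknown.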